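A chloro group added to compound 2

A few compounds are considered here, and "the series" means these few. Any claim that something is new, unique, unknown or untested is made for them only; others in the source may bear on it.

Compound 1 `O=C(Nc1cc(-c2ccccn2)n[nH]1)N1CCC(Oc2ccccc2)CC1` and compound 2 `O=C(Nc1cc(-c2ccccn2)n[nH]1)N1CCC(c2ccccc2)CC1` share a core and differ in one place. In an ADME assay on cells (Peritoneal macrophage cell, Mus musculus) for cytotoxicity, read by fluorescence and resazurin assay, with a stated time of 3 days (on this read-out lower numbers stand for higher toxicity in this test and higher numbers for lower toxicity in this test), compound 1 gives > 40000 nM as a limit of the assay and not as a number. In this assay compound 2 gives > 64000 nM as a limit too, so compound 2 stands on no exact number. Going by the values given here, the one measured step is a step that the two limits leave unreadable from compound 1 to compound 2 and it offers no size to carry forward.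

Compound 3 `O=C(Nc1cc(-c2ccccn2)n[nH]1)N1CCC(c2cccc(Cl)c2)CC1` departs from compound 2 by chloro in place of hydrogen on an aromatic carbon in the form of chloro in place of hydrogen on an aromatic carbon, meta to a large group, which reads as phenyl to 3-chlorophenyl. Among the compounds with values here, no measured step involves a chloro group, and neither measured compound supplies an exact starting number. A step beyond the usual scatter is therefore not expected in this assay in either direction, although this expectation rests on thin ground. The estimated step is an at least 1.1-fold lower number from compound 2 to compound 3 (0.06 log units; that floor lies within the scatter) and it should be read as a rough one. Compound 3 is expected at 55000 nM with an estimated range from 25000 nM to 110000 nM. A bare limit may well be the outcome again.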

Compound 3, half-maximal cytotoxic concentration: > 22000 nM
Compound 3 ended at the assay's limit; the forecaster's own chance of this, stated with the estimate: 70%; the middle value does not contradict the limit.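

Compound 3, like compound 1 and compound 2, stands at a limit and not at a number in this assay, so neither the step from compound 2 to compound 3 nor the step from compound 1 to compound 3 can be read. The compounds shown leave open whether chloro in place of hydrogen changes the read-out at all.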